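Aminothiophene ketones at the adenosine A3 receptor

This account rests on a few compounds, and the source may have more. Where it says the series, first, only, none or still open, it means among the compounds named here.

Compound 1 `CC(C)(C)Cc1c(-c2ccc(F)cc2F)sc(N)c1C(=O)c1ccc(Cl)cc1` — 1%
Compound 2 `CC(C)(C)Cc1c(-c2ccc(Cl)cc2)sc(N)c1C(=O)c1ccc(Cl)cc1` — 1%
Compound 3 `CC(C)(C)Cc1c(/C=C/c2ccc(Cl)cc2)sc(N)c1C(=O)c1ccc(Cl)cc1` — 11%

Of the compounds shown here, three sharing one core have been tested in an assay on CHO cells for displacement of a labelled ligand from adenosine receptor A3 (Homo sapiens), read by scintillation counting, tested at 10 uM; on this read-out lower numbers stand for less inhibition and higher numbers for more inhibition at the one concentration tested (going by the name of the read-out). Compound 1 gives 1%, compound 2 gives 1% and compound 3 gives 11%, the highest of the three numbers, though both steps up to it, a number 10 percentage points higher from compound 1 to compound 3 (within the scatter) and a number 10 percentage points higher from compound 2 to compound 3 (within the scatter), lie within the scatter, as does no change at the digits printed from compound 1 to compound 2 (within the scatter).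

Compound 4 `Cc1ccc(-c2sc(N)c(C(=O)c3ccc(Cl)cc3)c2CC(C)(C)C)cc1` carries the change (4-methylphenyl in place of 2-(4-chlorophenyl)ethenyl on an aromatic carbon). It thus returns to an aryl group bound directly to the ring, as in compound 1 and compound 2. Among the compounds with values here, the steps that bear on this are the two leading to compound 3, each within the scatter, so compound 4 is expected to fall back toward the numbers of compound 1 and compound 2, by a step of a number 9 percentage points lower from compound 3 to compound 4 (within the scatter) that stays within the scatter. Compound 4 is therefore estimated at 2% in this assay, with a range from 0% to 12%.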

Compound 4, a percentage reported as inhibition, at one concentration (the size of the read-out at that concentration, not a potency): 1%
Compound 4: middle estimate off by 1 percentage points, on the high side; measured number inside the range.
By their numbers in this assay, from the lowest: compounds 1, 2, 4 and 3 (each within the scatter of the next).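

At this position, next to the ring sulfur, this assay now covers three directly bound aryl groups, 2,4-difluorophenyl, 4-chlorophenyl and 4-methylphenyl, and does not tell them apart: methyl for chloro gives no change at the digits printed from compound 2 to compound 4 (within the scatter) and the change of 2,4-difluorophenyl gives no change at the digits printed from compound 1 to compound 4 (within the scatter). Replacing 2-(4-chlorophenyl)ethenyl with 4-methylphenyl gives a number 10 percentage points lower from compound 3 to compound 4 (within the scatter) and so, like the two earlier steps to the ethenyl compound, does not separate that group from the directly bound aryl groups. No evidence is at hand that would explain these numbers.

From the compounds shown here alone, whether a morpholine or a carboxylic acid in place of the aryl group would move the number beyond the scatter stays open. So does the role of the neopentyl and (4-chlorophenyl)carbonyl groups, which are the same in all four compounds.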